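The source may hold more compounds than are shown below. What is called first, only, known or untested is meant among the compounds shown, and "the series" means these compounds.

Measured compounds in a functional assay on PC-3 cells (Homo sapiens) for antiproliferative activity, read by MTT assay, tested at 1 uM; on this read-out higher numbers stand for a stronger effect at the one concentration tested and lower numbers for a weaker effect:
- compound 1, `COc1cc(C2=NN(C(C)=O)C(c3c(Cl)cccc3Cl)O2)cc(OC)c1OC`: 5.1%
- compound 2, `COc1cc(C2=NN(C(C)=O)C(c3ccc(F)cc3)O2)cc(OC)c1OC`: 0%
- compound 3, `COc1cc(C2=NN(C(C)=O)C(c3ccc(C(F)(F)F)cc3)O2)cc(OC)c1OC`: -11%

Compound 3 sits lowest of the three numbers in this assay. Its nearest neighbour is compound 2, the gap being a number 11 percentage points lower from compound 2 to compound 3 (beyond the scatter); the furthest is compound 1, with a number 16.1 percentage points lower from compound 1 to compound 3 (beyond the scatter). Both gaps lie beyond the scatter, so compound 3 is the weakest of the set as measured.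

The next compound, compound 4 `COc1cc(C2=NN(C(C)=O)C(c3cccc(C(F)(F)F)c3)O2)cc(OC)c1OC`, keeps the same atoms and differs from compound 3 only in how they are joined: 3-(trifluoromethyl)phenyl in place of 4-(trifluoromethyl)phenyl on a saturated ring carbon.

Going by the values given here, no measured step relocates a substituent on the pendant phenyl while keeping the group itself; the steps from compound 1 exchange the whole aryl group, and the step from compound 2 to compound 3 (a number 11 percentage points lower from compound 2 to compound 3 (beyond the scatter)) exchanges fluoro for trifluoromethyl at an unchanged place. All three steps are modest or within the scatter, and the whole set spans a narrow band of weak effect. A step no larger than the scatter is therefore expected, direction undetermined, the estimated step being a number 6 percentage points higher from compound 3 to compound 4 (within the scatter). Compound 4 is expected to give -5%, between -20% and 10%.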

Compound 4, a percentage reported as inhibition, at one concentration (the size of the read-out at that concentration, not a potency): 30.1%
Compound 4: middle estimate off by 35.1 percentage points, on the low side; measured number outside the range, above it.
By their numbers in this assay, from the lowest: compound 3; then compounds 2 and 1 (each within the scatter of the next); then compound 4.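

In this assay, 3-(trifluoromethyl)phenyl in place of 4-(trifluoromethyl)phenyl on the saturated ring carbon gives a number 41.1 percentage points higher from compound 3 to compound 4 (beyond the scatter) with no change in atoms, so at this position the arrangement of the same aryl group alone separates the two compounds. The 3-(trifluoromethyl)phenyl group also stands clear of the other two aryl groups, with a number 30.1 percentage points higher from compound 2 to compound 4 (beyond the scatter) and a number 25 percentage points higher from compound 1 to compound 4 (beyond the scatter) in the same assay, which makes compound 4 the strongest of the four as measured and takes the series out of the narrow weak band. Nothing at hand explains this result.

As far as these compounds go, whether the higher number belongs to trifluoromethyl itself or to any group placed the same way on the phenyl stays open; a 3-methoxyphenyl, 3-aminophenyl or 3-carboxyphenyl group would address that. Whether the effect grows with concentration also stays open, since only a single concentration is shown.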